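The source may report more compounds than this note shows. Statements on the series, on what has been measured and on what is new or still open speak of the compounds shown alone.

Measured in a functional assay on A549 cells (Homo sapiens) for antiproliferative activity, read by sulforhodamine B assay, with a stated time of 48 h (a lower number here means a stronger inhibitor, a higher number a weaker inhibitor), are these compounds
Compound 1 `COc1ccc2nc(-c3ccc(N/C=C\C(=O)c4ccc(OC)c(O)c4)c(C)c3)sc2c1` gives 18000 nM
Compound 2 `COc1cc(OC)c2sc(-c3ccc(N/C=C\C(=O)c4ccc(OC)c(O)c4)cc3)nc2c1` gives 10600 nM
Compound 3 `COc1ccc2nc(-c3ccc(N/C=C\C(=O)c4ccc(OC)c(O)c4)cc3)sc2c1` gives 12800 nM

Compound 3 at 12800 nM lies within the scatter of both compound 1 and compound 2. Compound 4 `COc1ccc2nc(-c3ccc(N/C=C\C(=O)c4ccc(OC)c([N+](=O)[O-])c4)cc3)sc2c1` differs from compound 3 as follows nitro in place of hydroxy on an aromatic carbon with nitro in place of hydroxy on an aromatic carbon, ortho to a methoxy group. Going by the values given here, the one measured step, hydrogen in place of methyl on an aromatic carbon, is a 1.4-fold lower number from compound 1 to compound 3 (0.15 log units; within the scatter) and lies within the scatter. It sits elsewhere, so no measurement addresses this change directly. In this assay no shift beyond the scatter is therefore expected, and the expected step is a 1.1-fold higher number from compound 3 to compound 4 (0.04 log units; within the scatter) without firm direction. Compound 4 is estimated at 14000 nM (expected range 6000 nM to 35000 nM).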

Compound 4, half-maximal inhibitory concentration: 13600 nM
The estimate for compound 4 lay 1.0-fold (0.01 log units) above the measured number; the range from low to high includes it.
By their numbers in this assay, from the lowest: compounds 2, 3, 4 and 1 (each within the scatter of the next).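

The change from 3-hydroxy-4-methoxyphenyl to 4-methoxy-3-nitrophenyl in this assay gives a 1.1-fold higher number from compound 3 to compound 4 (0.03 log units; within the scatter) and so stays within the scatter. Going by these compounds alone, the earlier compounds varied only elsewhere, so this is the first sign that this position, ortho to a methoxy group, can carry nitro instead of hydroxy, losing the hydrogen-bond donor, without a shift beyond the scatter. No evidence is available that bears on this result. Going by these compounds, whether an amine or a carboxylic acid here would move the number beyond the scatter stays open, as does replacing the methoxy group itself.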